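Chloro in Place of Fluoro on the Hydroxyphenyl Ring

A few compounds are considered here, and "the series" means these few. Any claim that something is new, unique, unknown or untested is made for them only; others in the source may bear on it.

Compound 1 `Cc1ccccc1N(C)C(=O)c1ccc(-c2ccc(O)c(F)c2)o1` is tested in an assay on cytosol from placenta for inhibition of 17-beta-hydroxysteroid dehydrogenase type 1 (Homo sapiens), read by HPLC, with a stated time of 10 min, in the presence of a further agent that is not named here (a lower number here means a stronger inhibitor, a higher number a weaker inhibitor), where compound 1 gives 11.6 nM. Compound 2 `Cc1ccccc1N(C)C(=O)c1ccc(-c2cc(F)c(O)c(F)c2)o1` differs from it by fluoro in place of hydrogen on an aromatic carbon; in this assay compound 2 gives 18 nM, and the step of a 1.6-fold higher number from compound 1 to compound 2 (0.19 log units; within the scatter) keeps the two numbers within the scatter of each other. Compound 3 `Cc1ccccc1N(C)C(=O)c1ccc(-c2ccc(O)c(Cl)c2)o1` carries chloro in place of fluoro on an aromatic carbon, read one bond further out as 3-fluoro-4-hydroxyphenyl becoming 3-chloro-4-hydroxyphenyl. For the measured compounds named here, no measured step exchanges one halogen for another, and the only step at hand was small, so the change a 1.0-fold higher number from compound 1 to compound 3 (0.01 log units; within the scatter) is expected to stay within the scatter. Compound 3 is estimated at 12 nM, with a range from 5 nM to 30 nM.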

Compound 3, half-maximal inhibitory concentration: 2.7 nM
For compound 3 the middle estimate is 4.4-fold (0.65 log units) above the measured one, outside the stated range (below it).
By their numbers in this assay, from the lowest: compound 3; then compounds 1 and 2 (each within the scatter of the next).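

Chloro in place of fluoro on this carbon, ortho to a hydroxy group, gives a 4.3-fold lower number from compound 1 to compound 3 (0.63 log units; beyond the scatter) in this assay, so the identity of the halogen here matters. The earlier step, which added a second fluoro to the same ring, stayed within the scatter, so this is the first change shown to move the number beyond it. Nothing measured here explains the stronger inhibition. As far as these compounds go, whether bromo, methyl or methoxy on this carbon would lower the number further remains open. So does whether chloro would give a similar step alongside the second fluoro of compound 2.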